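A few compounds are considered here, and "the series" means these few. Any claim that something is new, unique, unknown or untested is made for them only; others in the source may bear on it.

Measured compounds:
compound 1, `Fc1ccc(Oc2ccc(/C=N/NC(=S)Nc3ccc(Cl)cc3)cc2)cc1`, 5.84 in a physicochemical assay for lipophilicity, in phosphate buffer, measured as octanol-water partition, with a stated time of 24 h; a lower number here means a more polar compound, a higher number a more lipophilic compound;
compound 2, `Cc1ccc(Oc2ccc(/C=N/NC(=S)Nc3ccc(Br)cc3)cc2)cc1`, 6.17 in this assay;
compound 3, `S=C(N/N=C/c1ccc(Oc2ccccc2)cc1)Nc1ccc(Br)cc1`, 6.38 in this assay.

Compound 3 stands at the top of the three numbers in this assay, but compound 2 sits a number 0.21 log units higher from compound 2 to compound 3 (within the scatter), so the two cannot be told apart, while compound 1 lies further off, beyond the scatter. Compound 4, `S=C(N/N=C/c1ccc(Oc2ccccc2)cc1)Nc1ccc(Cl)cc1`, is not yet measured. It differs from compound 3 in one place: chloro in place of bromo on an aromatic carbon.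

Among the compounds with values here, no measured step isolates this exchange. Within the data shown here, the only single step recorded, a number 0.21 log units higher from compound 2 to compound 3 (within the scatter), concerns a methyl and a hydrogen and says nothing about the halogen. Among the measured compounds shown here, compound 1 and compound 2 carry chloro and bromo, yet they also differ on the other ring, so their values show only that the chloro compound gives the lower number without saying which change is responsible. The expectation therefore rests on the general behaviour of such halogen swaps rather than on a recorded step, and the expected step for compound 4 is a number 0.23 log units lower from compound 3 to compound 4 (within the scatter), small and downward, at the edge of the scatter. Compound 4 is accordingly estimated at 6.15 in this assay, with a range from 5.8 to 6.5.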

Compound 4, partition coefficient: 5.64
Compound 4: middle estimate off by 0.51 log units, on the high side, and the stated range ends above it.
By their numbers in this assay, from the lowest: compounds 4 and 1 (each within the scatter of the next); then compounds 2 and 3 (each within the scatter of the next).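

Within the data shown here, the exchange of bromo for chloro on an aromatic carbon, para to a large group, is now seen alone on the shared core: it gives a number 0.74 log units lower from compound 3 to compound 4 (beyond the scatter) in this assay, so this position answers to the choice of halogen by more than the scatter, which no earlier single step could show. On the other ring, hydrogen in place of fluoro gives a number 0.20 log units lower from compound 1 to compound 4 (within the scatter), so that pair cannot be told apart in this assay and this exchange, unlike the one at the halogen position, shows no readable change. Nothing in the material shown accounts for the size of the step from bromo to chloro.

Going by these compounds, it remains open whether the bromo to chloro step keeps its size when the other ring carries fluoro or methyl, since only the unsubstituted ring gives this exchange in isolation. How an amine, a carboxylic acid or a methoxy group on this same aromatic carbon would read in this assay is also open, as the compounds shown carry only bromo and chloro there.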